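Notes on compound 4 ahead of its measurement

The source may report more compounds than this note shows. Statements on the series, on what has been measured and on what is new or still open speak of the compounds shown alone.

Measured so far:
compound 1 `NC(=O)c1cn(Cc2ccccc2)c2ncnc(N)c12`, 75000 nM
compound 2 `Cc1ccccc1Cn1cc(C(N)=O)c2c(N)ncnc21`, > 100000 nM
compound 3 `Cc1ccccc1Cn1cc(C#N)c2c(N)ncnc21`, > 100000 nM

In a functional assay on KB cells (Homo sapiens) for cytotoxicity (a higher number here means a weaker inhibitor, a lower number a stronger inhibitor), compound 1 gives 75000 nM. Compound 2 reaches only a limit, > 100000 nM. Compound 3 likewise reaches only a limit, > 100000 nM. Compound 2 therefore stands at the weak end of the numbers shown, with the limit of > 100000 nM in this assay, at which 2 of the 3 values shown sit, marking where it sits. Compound 4 `C=CCn1cc(C(N)=O)c2c(N)ncnc21` is not yet measured; (vinyl in place of 2-methylphenyl on a saturated chain carbon bound to an aromatic nitrogen). Going by the values given here, the steps that bear on it are an at least 1.3-fold higher number from compound 1 to compound 2 (0.12 log units; that floor lies within the scatter) and a step that the two limits leave unreadable from compound 2 to compound 3, neither of which gives a readable size. No step beyond the scatter is expected in this assay; compound 4 is estimated at 100000 nM, between 40000 nM and 300000 nM, which is expected to mean a number no higher from compound 2 to compound 4 (the limit leaves the size open).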

Compound 4, half-maximal inhibitory concentration: 100000 nM
Estimate against measurement, compound 4: no gap at the digits printed; the range from low to high includes it.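

In this assay, the change from phenyl to vinyl on a saturated chain carbon bound to an aromatic nitrogen gives a 1.3-fold higher number from compound 1 to compound 4 (0.12 log units; within the scatter). Going by these compounds alone, this is the first readable step at this position, and it shows that an aromatic ring is not needed there to hold a value in this range. The change from 2-methylphenyl to vinyl on the same carbon gives a number no higher from compound 2 to compound 4 (the limit leaves the size open). The size of this step cannot be read, since the value of compound 2 is a limit: the limit of > 100000 nM in this assay, at which 2 of the 4 values shown sit.

From the compounds shown here alone, whether any group at this position brings the number down beyond the scatter stays open. An amine, a carboxylic acid or a longer chain in place of vinyl would test this.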